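Replacing 1,3-benzoxazol-2-yl in compound 3

The compounds below may be only part of what the source reports. "The series", "measured", "known", "first", "only" and "open" are said of these compounds alone.

In a functional assay on HeLa cells (Homo sapiens) for inhibition, read by MTT assay, with a stated time of 72 h (a lower number here means a stronger inhibitor, a higher number a weaker inhibitor), compound 1 (`Cc1ccc(-c2nnc(SCCCN3CCN(c4nc5ccccc5o4)CC3)o2)cc1`) gives 133000 nM, compound 2 (`Fc1ccc(-c2nnc(SCCCN3CCN(c4nc5ccccc5o4)CC3)o2)cc1`) gives 196000 nM and compound 3 (`CC(C)(C)Oc1ccc(-c2nnc(SCCCN3CCN(c4nc5ccccc5o4)CC3)o2)cc1`) gives 269000 nM. Two gaps fix the place of compound 3 among them: a 1.4-fold higher number from compound 2 to compound 3 (0.14 log units; within the scatter), and a 2.0-fold higher number from compound 1 to compound 3 (0.31 log units; beyond the scatter). Compound 4 (`CC(C)(C)Oc1ccc(-c2nnc(SCCCN3CCN(c4nc5ccccc5s4)CC3)o2)cc1`) carries 1,3-benzothiazol-2-yl in place of 1,3-benzoxazol-2-yl on an amine nitrogen in a ring. For the measured compounds named here, no measured step touches this group, so the evidence is indirect. Changes on an aromatic carbon moved the numbers only slightly, as in a 1.5-fold higher number from compound 1 to compound 2 (0.17 log units; within the scatter), and no step beyond the scatter is expected in this assay. The expected change is a 1.3-fold lower number from compound 3 to compound 4 (0.13 log units; within the scatter). Compound 4 is estimated at 200000 nM, with a range of 90000 nM to 400000 nM.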

Compound 4, half-maximal inhibitory concentration: 217000 nM
For compound 4 the middle estimate is 1.1-fold (0.04 log units) below the measured one; low and high end bracket the measured number.
By their numbers in this assay, from the lowest: compounds 1, 2, 4 and 3 (each within the scatter of the next, the first and the last beyond it).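

For the compounds shown here, this is the first measured change on an amine nitrogen in a ring rather than on an aromatic carbon. In this assay putting 1,3-benzothiazol-2-yl in place of 1,3-benzoxazol-2-yl, which exchanges one ring oxygen for sulfur, gives a 1.2-fold lower number from compound 3 to compound 4 (0.09 log units; within the scatter) and so the two compounds cannot be told apart at this position. No measured property is available to explain this result.

Going by these compounds, whether a plain phenyl or a pyridin-2-yl group on that nitrogen would behave the same stays open. So does whether this exchange would read alike with methyl or fluoro in place of tert-butoxy.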